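From Thiophen-2-yl to 4-Fluorophenyl: Expected Cytotoxicity

The source may report more compounds than this note shows. Statements on the series, on what has been measured and on what is new or still open speak of the compounds shown alone.

Of the compounds shown here, three have so far been tested in an ADME assay on HepG2 2.2.15 cells (Homo sapiens) for cytotoxicity; on this read-out higher numbers stand for lower toxicity in this test and lower numbers for higher toxicity in this test. Compound 1 `Cc1ccc(C(=O)Nc2ncc(Cc3ccc(F)cc3)s2)cc1` gives "not toxic" (no number reported) in this assay. For compound 2 `CC(C)(C)OC(=O)Nc1ncc(C(Oc2ccc(F)c(Cl)c2)c2ccc(Cl)cc2)s1` only a limit of the assay is recorded, namely > 50000 nM. Compound 3 `O=C(Nc1ncc(C(Oc2ccc3cc(Br)ccc3c2)c2ccc(Cl)cc2)s1)c1cccs1` in turn gives "not toxic" (no number reported), again without a number attached. Compound 3 thus stands where the other two stand: none of the three shows a measurable toxic concentration, and one of the three sits at the limit of > 50000 nM in this assay, at which 1 of the 3 values shown sits.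

Compound 4 `O=C(Nc1ncc(C(Oc2ccc3cc(Br)ccc3c2)c2ccc(Cl)cc2)s1)c1ccc(F)cc1` differs from compound 3 by 4-fluorophenyl in place of thiophen-2-yl on a carbonyl carbon. Within the data shown here, for this change no measured step exists in this assay. A shift beyond the usual scatter is not expected in this assay, because compound 3 gives "not toxic" (no number reported). Compound 4 is therefore expected to reach 60000 nM, with a range from 30000 nM to 120000 nM.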

Compound 4, half-maximal cytotoxic concentration: "not toxic" (no number reported)
The entry for compound 4 holds no number, so the estimate cannot be set against anything.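

Compound 3 and compound 4 both carry no number in this assay, so no step can be read between them. The compounds shown leave open at what concentration any of them turns toxic, and the only figure, from compound 2, is a limit: the limit of > 50000 nM in this assay, at which 1 of the 4 values shown sits.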